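Methoxy addition on the aryl ring: notes toward compound 4

The source may report more compounds than this note shows. Statements on the series, on what has been measured and on what is new or still open speak of the compounds shown alone.

Compound 1 `C=C(C)[C@@H]1CC=C(Cn2cc(COc3cccc(C4NC(=O)NC(C)=C4C(=O)OCC)c3)nn2)CC1`: 508000 nM
Compound 2 `C=C(C)[C@@H]1CC=C(Cn2cc(COc3cc(C4NC(=O)NC(C)=C4C(=O)OCC)ccc3OC)nn2)CC1`: 79800 nM
Compound 3 `C=C(C)[C@@H]1CC=C(Cn2cc(COc3ccc(C4NC(=O)NC(C)=C4C(C)=O)cc3)nn2)CC1`: 44500 nM

All three were run in an ADME assay on HaCaT cells (Homo sapiens) for inhibition, read by sulforhodamine B assay, with a stated time of 48 h (on this read-out lower numbers stand for stronger inhibition of growth and higher numbers for weaker inhibition of growth), at the stated time. The change from compound 1 to compound 2 is methoxy in place of hydrogen on an aromatic carbon and it gave a 6.4-fold lower number from compound 1 to compound 2 (0.80 log units; beyond the scatter) on this read-out. Compound 3 has a different core; the difference between the cores of compound 1 and compound 3 is not broken down here. Compound 3 gives a number within the scatter of compound 2 and well under that of compound 1.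

Compound 4 `C=C(C)[C@@H]1CC=C(Cn2cc(COc3ccc(C4NC(=O)NC(C)=C4C(C)=O)cc3OC)nn2)CC1` is not yet measured and differs from compound 3 by methoxy in place of hydrogen on an aromatic carbon. This is the same kind of change as in compound 2, but the place differs: in compound 4 the methoxy is ortho to a large group and meta to a large group, whereas in compound 2 it is ortho to a large group and para to a large group. For the measured compounds named here, for compound 4 the expected step in this assay is a 3.0-fold lower number from compound 3 to compound 4 (0.47 log units; beyond the scatter) and rests on the single earlier step of a 6.4-fold lower number from compound 1 to compound 2 (0.80 log units; beyond the scatter) together with the changed place. Compound 4 is thus expected near 15000 nM with the usual range from 5000 nM up to 40000 nM in this assay.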

Compound 4, concentration for total growth inhibition: 148000 nM
Compound 4: middle estimate off by 9.9-fold (0.99 log units), on the low side; measured number outside the range, above it.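

In this assay, methoxy in place of hydrogen on an aromatic carbon gives a 3.3-fold higher number from compound 3 to compound 4 (0.52 log units; beyond the scatter), so the direction of the earlier step does not carry over to this core: the same change on two cores in this assay, a 6.4-fold lower number (0.80 log units; beyond the scatter) from compound 1 to compound 2 and a 3.3-fold higher number (0.52 log units; beyond the scatter) from compound 3 to compound 4, 21-fold (1.33 log units) apart, beyond the scatter of two such steps

A lower number on the core of compound 1 therefore cannot be assumed for the same change on another core in this series. The data do not show what reverses the step, since the two steps differ in both core and the place of the methoxy, here ortho to a large group and meta to a large group.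

Still open, on these data alone, is whether methoxy at one shared place would move the number the same way on both cores. Also open, as far as these compounds go, is whether ethoxy, hydroxy or fluoro at this place on the core of compound 3 would follow methoxy.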